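Swapping aminomethyl for 4-methylphenyl on a triazole core

The source may hold more compounds than are shown below. What is called first, only, known or untested is meant among the compounds shown, and "the series" means these compounds.

Three compounds share one core, and their toxicity toward mouse spleen cells was followed in an ADME assay on cells (spleen, Mus musculus, strain C57BL/6) for inhibition, read by flow cytometry and propidium iodide staining, with a stated time of 24 h, at 37 degrees C; a higher number here means that more compound is needed for the effect, a lower number that less compound is needed. Compound 1, `O=C(O)CCc1cn(CC(=O)NCc2ccccc2)nn1`, gives 1420 uM in this assay. Compound 2, `NCc1cn(CC(=O)NCc2ccccc2)nn1`, gives only a limit, > 2000 uM, which marks the highest concentration tested rather than a number; this is the limit of > 2000 uM in this assay, at which 1 of the 2 values shown sits. Within the data shown here, the one measured step, an at least 1.4-fold higher number from compound 1 to compound 2 (0.14 log units; that floor lies within the scatter), therefore sets a floor, not a size, and it concerns a change at a saturated chain carbon.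

Compound 3 is `Cc1ccc(-c2cn(CC(=O)NCc3ccccc3)nn2)cc1`. It differs from compound 2 by 4-methylphenyl in place of aminomethyl on an aromatic carbon. No measured step touches an aromatic ring entering in place of a chain group, so the change from compound 2 to compound 3 stands without a direct precedent among these compounds. Compound 3 is nonetheless expected to sit somewhat lower than the limit of compound 2, since compound 2 cannot move higher than its limit > 2000 uM. For compound 3 the estimate in this assay is 800 uM, within 200 uM to 2000 uM. That estimate corresponds to a step of an at least 2.5-fold lower number from compound 2 to compound 3 (0.39 log units; beyond the scatter), expected rather than measured.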

Compound 3, concentration for half-maximal effect: "non-toxic" (no number reported)
No number was reported for compound 3; there is nothing to compare the estimate with.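

Among these compounds, compound 3 is reported in this assay only as "non-toxic", without a number, and compound 2 has only a limit, so no step from compound 2 to compound 3 can be read. The compounds shown leave open how far, and in which direction, 4-methylphenyl in place of aminomethyl moves the number.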